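Shortening the Aryl Arm: From Compound 3 to Compound 4

A few compounds are considered here, and "the series" means these few. Any claim that something is new, unique, unknown or untested is made for them only; others in the source may bear on it.

In an assay on liver for inhibition of sterol O-acyltransferase 1 (Rattus norvegicus), using microsomes (on this read-out higher numbers stand for weaker inhibition and lower numbers for stronger inhibition), compound 3 `CCCCCCCCCCCCn1nnc(C(C(=O)Nc2c(OC)cc(OC)cc2OC)c2ccc(-c3ccccc3)cc2)n1` gives 221 nM, the highest of the three numbers recorded here. Compound 2 `CCCCCCCCCCCCn1nnc(C(C(=O)Nc2c(OC)cc(OC)cc2OC)c2ccc(OC)cc2)n1` gives 200 nM, and the step of a 1.1-fold higher number from compound 2 to compound 3 (0.04 log units; within the scatter) stays within the scatter. Compound 1 `CCCCCCCCCCCCn1nnc(C(C(=O)Nc2c(OC)ncnc2OC)c2ccccc2)n1` gives 13 nM, a much lower number than compound 3, but it differs from compound 3 in more than one place. Compound 4 `CCCCCCCCCCCCn1nnc(C(Cc2ccccc2)C(=O)Nc2c(OC)cc(OC)cc2OC)n1` differs from compound 3 by benzyl in place of 4-phenylphenyl on a saturated chain carbon bound to an aromatic carbon and a carbonyl carbon. Within the data shown here, no measured step covers a change of this kind; the one single-place step recorded, an exchange of one aromatic substituent for another, stayed within the scatter. Compound 4 is therefore expected to give about 300 nM in this assay, within a range of 80 nM to 1200 nM, an expected step of a 1.4-fold higher number from compound 3 to compound 4 (0.13 log units; within the scatter) that need not exceed the scatter.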

Compound 4, half-maximal inhibitory concentration: 490 nM
For compound 4 the middle estimate is 1.6-fold (0.21 log units) below the measured one, within the range that was stated.
By their numbers in this assay, from the lowest: compound 1; then compounds 2 and 3 (each within the scatter of the next); then compound 4.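

In this assay benzyl in place of 4-phenylphenyl on this saturated chain carbon brings a 2.2-fold higher number from compound 3 to compound 4 (0.35 log units; beyond the scatter) and benzyl in place of 4-methoxyphenyl brings a 2.5-fold higher number from compound 2 to compound 4 (0.39 log units; beyond the scatter) as well. Both modest steps lie beyond the scatter, so replacing the whole aryl group at this carbon moves the number, whereas the exchange of one aromatic substituent for another did not. No accompanying measurement bears on what lies behind this rise. As far as these compounds go, whether an amine, a carboxylic acid or a longer chain at this carbon would lower the number remains open.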